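Working notes: from compound 2 to compound 3

The compounds below may be only part of what the source reports. "The series", "measured", "known", "first", "only" and "open" are said of these compounds alone.

Compound 1 `COc1cc(O)c(CC=C(C)C)c(O)c1C(=O)/C=C/c1ccc(Cl)cc1`: 10100 nM
Compound 2 `COc1cc(OC)c(C(=O)/C=C/c2ccc(O)cc2)c(OC)c1`: 37000 nM

In a functional assay on HepG2 cells (Homo sapiens) for inhibition, read by MTT assay, with a stated time of 72 h (on this read-out higher numbers stand for weaker inhibition and lower numbers for stronger inhibition), compound 2 gives 37000 nM, the higher of the two numbers and so the weaker inhibition. Compound 1 gives 10100 nM, and this gap lies beyond the usual scatter.

Compound 3 `COc1cc(OC)c(C(=O)/C=C/c2ccccc2OC)c(OC)c1` has not yet been measured. It carries 2-methoxyphenyl in place of 4-hydroxyphenyl on a double-bonded chain carbon bound to a double-bonded chain carbon. Going by the values given here, no pair of measured compounds isolates this change, so the data give no direct guide to its size in this assay. A small move towards a lower number is expected, probably not beyond the scatter. This expectation rests weakly on compound 1 at 10100 nM, which shows that a lower number occurs among these compounds, although it differs from compound 2 in more than one place. The expected change is a 1.7-fold lower number from compound 2 to compound 3 (0.23 log units; within the scatter). For compound 3 the estimated value is 22000 nM, with an expected range from 7000 nM to 70000 nM.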

Compound 3, half-maximal inhibitory concentration: 16300 nM
Compound 3: the middle estimate sits 1.3-fold (0.13 log units) above what was measured; the measured number falls inside the stated range.
By their numbers in this assay, from the lowest: compounds 1 and 3 (each within the scatter of the next); then compound 2.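

In this assay, going by these compounds alone, placing 2-methoxyphenyl in place of 4-hydroxyphenyl on a double-bonded chain carbon bound to a double-bonded chain carbon gives a 2.3-fold lower number from compound 2 to compound 3 (0.36 log units; beyond the scatter) and provides the first reading of a change at a single place. The step is modest but lies beyond the scatter, so this position does affect the read-out, and the shared core is not the only part that matters. The leaving group carries 1 hydrogen-bond donor and the entering group 0, so in this pair a hydrogen-bond donor on the aromatic ring is not required for the lower number, and nothing measured here explains the shift.

Two things change together in this step, the loss of the hydroxy group and the arrival of a methoxy group at a different place on the ring, and this single pair cannot separate their contributions. Going by these compounds, it also remains open how this position would respond to a dimethylamino group or a carboxylic acid on the ring, and whether the direction of the step would hold for such groups.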